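Aryl swap on a series sitting at the assay limit

The source may report more compounds than this note shows. Statements on the series, on what has been measured and on what is new or still open speak of the compounds shown alone.

Three analogues on one shared core have been run in an assay on cells for inhibition of S-adenosylmethionine decarboxylase proenzyme (Homo sapiens), read by mass spectrometry, at pH 7.2; on this read-out higher numbers stand for weaker inhibition and lower numbers for stronger inhibition. Compound 1 `Cc1cc(Nc2cc(Cl)cc(Cl)c2)nc(N(C)C)n1` gives > 180000 nM, which is a limit of the assay rather than a number. Compound 2 `Cc1cc(Nc2cc(Cl)cc(S(F)(F)(F)(F)F)c2)nc(N)n1` gives > 180000 nM in this assay, again a limit. Compound 3 `Cc1cc(Nc2cc(Br)cc(S(F)(F)(F)(F)F)c2)nc(N)n1` gives > 180000 nM in this assay, also a limit. For the measured compounds named here, the only single-point step, a step that the two limits leave unreadable from compound 2 to compound 3, cannot be read because both ends sit at the limit (the limit of > 180000 nM in this assay, at which 3 of the 3 values shown sit). So compound 3 stands where every measured member stands: at the limit, with no number that would rank it against the others.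

Compound 4 `Cc1cc(Nc2cc(Br)cc(OCC(F)(F)F)c2)nc(N)n1` differs from compound 3 by a group of 6 heavy atoms (2 carbon, 1 oxygen, 3 fluorine; no ring) in place of a group of 6 heavy atoms (5 fluorine, 1 sulfur; no ring), on an aromatic carbon. Going by the values given here, no measured step bears on this change; the one step available, from compound 2 to compound 3, is unreadable. With nothing to build on, the expectation for compound 4 in this assay is that it behaves as compound 3 does, so the step that the limit leaves unreadable from compound 3 to compound 4 is expected to be none beyond the scatter. The estimate for compound 4 is 200000 nM, between 50000 nM and 600000 nM, and most likely the assay again returns only a limit.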

Compound 4, half-maximal inhibitory concentration: 44000 nM
For compound 4 the middle estimate is 4.5-fold (0.66 log units) above the measured one; the whole stated range lies above it.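

For the compounds shown here, with the bromo group and the rest of the shared core held fixed, placing 2,2,2-trifluoroethoxy on this aromatic carbon in place of the group of 5 fluorine and 1 sulfur gives the first readable step in this assay: an at least 4.0-fold lower number from compound 3 to compound 4 (0.61 log units; beyond the scatter). Compound 4, at 44000 nM, is the only member shown with a number, so this aromatic carbon is a place where a change yields a readable value, something the unreadable swap of chloro for bromo between compound 2 and compound 3 could not show. The step is a bound rather than a size, because compound 3 gives only a limit: the limit of > 180000 nM in this assay, at which 3 of the 4 values shown sit.

The compounds shown leave open whether the oxygen or the fluorines of 2,2,2-trifluoroethoxy carry the change, a question that a methoxy group, an ethoxy group or a longer chain on this aromatic carbon would address. Also open, from the compounds shown here alone, is whether chloro in place of bromo, or dimethylamino in place of the amino group on the shared core, would keep a readable number alongside 2,2,2-trifluoroethoxy.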